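A Chloro Group Tried on a Potent Ring-Fused Amine

A few compounds are considered here, and "the series" means these few. Any claim that something is new, unique, unknown or untested is made for them only; others in the source may bear on it.

Measured compounds:
Compound 1, `CC[C@H]1c2nc3ccccc3cc2[C@@H]2CCN(C)[C@@H]3CCC[C@H]1[C@H]32`, gives 189 nM in an assay on isolated protein for displacement of a labelled ligand from Sigma non-opioid intracellular receptor 1 (Cavia porcellus), read by scintillation counting, with a stated time of 90 min; on this read-out higher numbers stand for weaker inhibition and lower numbers for stronger inhibition.
Compound 2, `CCCN1CC[C@H]2c3cc4ccccc4nc3[C@H](CC)[C@H]3CCC[C@@H]1[C@@H]32`, gives 70 nM in this assay.

Among the measured compounds shown here, compound 2 stands lowest of the two numbers measured so far; its nearest neighbour is compound 1, and the step of a 2.7-fold lower number from compound 1 to compound 2 (0.43 log units; beyond the scatter) lies beyond the scatter, so compound 2 binds more strongly. That step comes from an ethyl in place of hydrogen on a saturated chain carbon bound to an amine nitrogen in a ring.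

Compound 3, `CCCN1CC[C@H]2c3cc4cc(Cl)ccc4nc3[C@H](CC)[C@H]3CCC[C@@H]1[C@@H]32`, has not yet been measured. It differs from compound 2 by chloro in place of hydrogen on an aromatic carbon. For the measured compounds named here, none of the measured steps touches this aromatic carbon; the only step seen, from a change at the amine side chain, says nothing about a chloro group on the ring. Going by the values given here, with no comparable step to draw on, no change beyond the scatter is expected in this assay, and the range must stay wide.

Compound 3 is therefore expected to give about 70 nM, within 25 nM to 200 nM.

The expected step of no change at the digits printed from compound 2 to compound 3 (within the scatter) is estimated to stay within the scatter.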

Compound 3, inhibition constant: 209 nM
For compound 3 the middle estimate is 3.0-fold (0.48 log units) below the measured one; the whole stated range lies below it.
By their numbers in this assay, from the lowest: compound 2; then compounds 1 and 3 (each within the scatter of the next).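

In this assay, chloro in place of hydrogen on this aromatic carbon, which is meta to a fused ring and para to a fused ring, gives a 3.0-fold higher number from compound 2 to compound 3 (0.48 log units; beyond the scatter) and so weakens binding. This shows that the six-membered aromatic ring of carbon only is not a neutral place for change: adding a single heavy atom here is enough to move the number beyond the scatter. Among the compounds shown here, the only earlier step, at the amine side of the molecule, ran the other way (a 2.7-fold lower number from compound 1 to compound 2 (0.43 log units; beyond the scatter)), so the two edits to the shared core have so far pulled binding in opposite directions, and nothing available accounts for the loss seen with chloro.

From the compounds shown here alone, it remains open whether this weaker binding is particular to chloro or would also appear with another group on the same aromatic carbon, such as fluoro, methoxy or a nitrile. It is equally unknown whether chloro would give a similar step on another carbon of this ring, or whether a hydroxyl group there would behave differently.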